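Isobutyl in Place of Cyclopropyl on the Carbonyl Carbon

The compounds below may be only part of what the source reports. "The series", "measured", "known", "first", "only" and "open" are said of these compounds alone.

Of the compounds shown here, two built on a shared core have been measured in a physicochemical assay for solubility, read by HPLC; a lower number here means a less soluble compound, a higher number a more soluble compound. Compound 1 `O=C(C1CC1)N1CCN(c2nc(=O)c3cc(C(F)(F)F)cc([N+](=O)[O-])c3s2)CC1` gives 52.9 ug/mL in this assay, the lowest of the two numbers. Compound 2 `CCC(C)C(=O)N1CCN(c2nc(=O)c3cc(C(F)(F)F)cc([N+](=O)[O-])c3s2)CC1` carries sec-butyl in place of cyclopropyl on a carbonyl carbon, and in this assay compound 2 gives 104 ug/mL. The step of a 2.0-fold higher number from compound 1 to compound 2 (0.29 log units; within the scatter) stays within the scatter of repeated measurements, so the two values cannot be ranked with confidence.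

Compound 3 `CC(C)CC(=O)N1CCN(c2nc(=O)c3cc(C(F)(F)F)cc([N+](=O)[O-])c3s2)CC1` has not yet been measured. It differs from compound 1 in one place: isobutyl in place of cyclopropyl on a carbonyl carbon. Among the compounds with values here, the only measured step bearing on this change is the one from compound 1 to compound 2, where sec-butyl replaced the same cyclopropyl on the same carbonyl carbon and the number moved only within the scatter. For the present change, a similar outcome is expected: no step beyond the scatter, perhaps a small rise. The step of a 1.6-fold higher number from compound 1 to compound 3 (0.21 log units; within the scatter) is expected to remain within the scatter because the step of a 2.0-fold higher number from compound 1 to compound 2 (0.29 log units; within the scatter) did. Compound 3 is therefore estimated at 85 ug/mL, with a range from 40 ug/mL to 180 ug/mL.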

Compound 3, solubility: 66.3 ug/mL
Compound 3: the middle estimate sits 1.3-fold (0.11 log units) above what was measured; the range from low to high includes it.
By their numbers in this assay, from the lowest: compounds 1, 3 and 2 (each within the scatter of the next).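

In this assay, the step of a 1.3-fold higher number from compound 1 to compound 3 (0.10 log units; within the scatter) shows that replacing the cyclopropyl ring on the carbonyl carbon with the open isobutyl chain does not separate compound 3 from compound 1 in this read-out. The two open chains can now also be compared directly, and the step of a 1.6-fold lower number from compound 2 to compound 3 (0.20 log units; within the scatter) shows that exchanging sec-butyl for isobutyl at the same place does not separate the two compounds either, so cyclopropyl, sec-butyl and isobutyl cannot be ranked here. No measurement shown here offers an explanation for these results.

All three groups compared at this place contain only carbon, so the compounds shown do not reveal what an amine, a carboxylic acid or a longer chain on the carbonyl carbon would do. As far as these compounds go, whether any of these groups would produce a step beyond the scatter remains open, as does whether a change elsewhere on the shared core would do so.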